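The source may report more compounds than this note shows. Statements on the series, on what has been measured and on what is new or still open speak of the compounds shown alone.

Measured so far in a functional assay on MT2 cells (Homo sapiens) for antiproliferative activity, read by MTT assay, with a stated time of 72 h; a lower number here means a stronger inhibitor of growth, a higher number a weaker inhibitor of growth:

compound 1 `O=C(COc1ccc2oc(-c3ccccc3)cc(=O)c2c1)Nc1ccc(F)cc1` — 470 nM
compound 2 `COc1ccc(NC(=O)COc2ccc3oc(-c4ccccc4)cc(=O)c3c2)cc1` — 3010 nM
compound 3 `O=C(COc1ccc2c(=O)c(-c3ccccc3)coc2c1)Nc1ccc(F)cc1` — 2500 nM

Compound 1 and compound 3 are built from the same atoms joined differently; the difference between the two cores is not broken down here. Compound 3 stands close to compound 2, within the scatter, and clearly above compound 1.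

On the core of compound 1 the change methoxy in place of fluoro on an aromatic carbon gives a 6.4-fold higher number from compound 1 to compound 2 (0.81 log units; beyond the scatter), a modest loss of potency.

Compound 4 `COc1ccc(NC(=O)COc2ccc3c(=O)c(-c4ccccc4)coc3c2)cc1` is not yet measured in this assay. It is reached from compound 3 by methoxy in place of fluoro on an aromatic carbon, the same change at the same place as from compound 1 to compound 2, only on the other core. Among the compounds with values here, a step of similar size is expected, because a 6.4-fold higher number from compound 1 to compound 2 (0.81 log units; beyond the scatter) is the only measured instance of this change and nothing here suggests the second core behaves differently; the expected step is a 4.0-fold higher number from compound 3 to compound 4 (0.60 log units; beyond the scatter). Compound 4 is therefore estimated at 10000 nM in this assay, with a plausible range from 3500 nM to 30000 nM.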

Compound 4, concentration for 50% growth inhibition: 4550 nM
Compound 4: middle estimate off by 2.2-fold (0.34 log units), on the high side; the range from low to high includes it.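

In this assay methoxy in place of fluoro on an aromatic carbon gives a 1.8-fold higher number from compound 3 to compound 4 (0.26 log units; within the scatter) and so does not separate the two compounds on this core. The change does not carry over at one size from the core of compound 1 to the core of compound 3: the same change on two cores in this assay, a 6.4-fold higher number (0.81 log units; beyond the scatter) from compound 1 to compound 2 and a 1.8-fold higher number (0.26 log units; within the scatter) from compound 3 to compound 4, 3.5-fold (0.55 log units) apart, beyond the scatter of two such steps. This shows that, within these four compounds, the size of the step depends on the core; it rests on a single pair per core, so it sets no rule for the series and gives no reason for the gap.

Still open, from the compounds shown here alone, is how a chloro, a nitrile or an amine at the same place on the aromatic ring would read on each core, and whether the two cores would again part. Also open, going by these compounds, is whether a longer chain between the core and the amide would keep the difference between the two methoxy and fluoro pairs.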